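The source may report more compounds than this note shows. Statements on the series, on what has been measured and on what is new or still open speak of the compounds shown alone.

Measured compounds and their values in a functional assay on Ehrlich cells (Mus musculus) for cytotoxicity, tested at 10 ug/mL; on this read-out lower numbers stand for a weaker effect and higher numbers for a stronger effect at the one concentration tested:

compound 1, `COc1cc(N2C(N)=C(C#N)C(c3ccc([N+](=O)[O-])cc3)C3=C2CC(C)(C)CC3=O)cc(OC)c1OC`: 10%
compound 2, `COc1cc(N2C(N)=C(C#N)C(c3c(O)ccc4ccccc34)C3=C2CC(C)(C)CC3=O)cc(OC)c1OC`: 2%
compound 3, `COc1cc(N2C(N)=C(C#N)C(c3cccc([N+](=O)[O-])c3)C3=C2CC(C)(C)CC3=O)cc(OC)c1OC`: 5%

All three compounds share one core and differ only in the group on a saturated ring carbon. On the numbers shown, compound 3 sits within the scatter of both neighbours: the step of a number 3 percentage points higher from compound 2 to compound 3 (within the scatter) and the step of a number 5 percentage points lower from compound 1 to compound 3 (within the scatter) are each too small to be read as a change, so none of the three can be called stronger or weaker than another in this assay.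

Compound 4, `COc1ccccc1C1C(C#N)=C(N)N(c2cc(OC)c(OC)c(OC)c2)C2=C1C(=O)CC(C)(C)C2`, has not yet been measured. It differs from compound 3 in one place: 2-methoxyphenyl in place of 3-nitrophenyl on a saturated ring carbon.

Every step measured so far bears on this change, since each swaps the group on the same saturated ring carbon: a number 8 percentage points lower from compound 1 to compound 2 (within the scatter), a number 5 percentage points lower from compound 1 to compound 3 (within the scatter) and a number 3 percentage points higher from compound 2 to compound 3 (within the scatter). All three stayed within the scatter, so for compound 4 no step beyond the scatter is expected in this assay. Compound 4 is therefore estimated at 5%, with a range from 0% to 14%. The step this estimate implies is no change at the digits printed from compound 3 to compound 4 (within the scatter), expected to be within the scatter.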

Compound 4, a percentage reported as activity, at one concentration (the size of the read-out at that concentration, not a potency): 30%
Compound 4: middle estimate off by 25 percentage points, on the low side, outside the stated range (above it).
By their numbers in this assay, from the lowest: compounds 2, 3 and 1 (each within the scatter of the next); then compound 4.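

For the compounds shown here, the saturated ring carbon, where the earlier swaps could not be told apart, proves able to move the read-out in this assay: 2-methoxyphenyl in place of 3-nitrophenyl gives a number 25 percentage points higher from compound 3 to compound 4 (beyond the scatter) and so separates a group on this carbon from the others for the first time. The same holds against the other two groups, with a number 28 percentage points higher from compound 2 to compound 4 (beyond the scatter) for the swap from 2-hydroxynaphthalen-1-yl and a number 20 percentage points higher from compound 1 to compound 4 (beyond the scatter) for the swap from 4-nitrophenyl, which makes compound 4 the strongest of the four at the one concentration tested, though all three steps remain modest. Nothing available accounts for why 2-methoxyphenyl stands apart from the other groups.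

The compounds shown leave open whether the methoxy group itself carries this step, as they include no plain phenyl on this carbon and no ethoxy chain or amino group in place of the methoxy group. They also leave open whether the stronger effect of compound 4 at the one concentration tested would hold at other concentrations.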